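Methoxy Added to a Trifluoromethyl Amidine

The compounds below may be only part of what the source reports. "The series", "measured", "known", "first", "only" and "open" are said of these compounds alone.

Compound 1 `N=C(NCCC(O)c1ccccc1N)c1ccc(Cl)cc1`: 73.2%
Compound 2 `N=C(NCCC(O)c1ccccc1N)c1ccc(C(F)(F)F)cc1`: 60.5%
Compound 3 `COc1ccc(N)c(C(O)CCNC(C)=N)c1`: 57.4%

In an assay for inhibition of Nitric oxide synthase, inducible (Homo sapiens), with a stated time of 30 min, tested at 1 mM (on this read-out lower numbers stand for less inhibition and higher numbers for more inhibition at the one concentration tested (going by the name of the read-out)), compound 2 stands second highest of the three numbers, with compound 3 giving 57.4% within the scatter of it, and compound 1 giving 73.2% beyond. Among the measured compounds shown here, the single measured step, a number 12.7 percentage points lower from compound 1 to compound 2 (beyond the scatter), concerns the trifluoromethyl in place of chloro and does not bear on the change here. Compound 4 `COc1ccc(N)c(C(O)CCNC(=N)c2ccc(C(F)(F)F)cc2)c1` differs from compound 2 by methoxy in place of hydrogen on an aromatic carbon. For the measured compounds named here, no measured step for a methoxy entering is available, and compound 3, which carries a methoxy, sits within the scatter of compound 2. For compound 4 a step of a number 2.5 percentage points lower from compound 2 to compound 4 (within the scatter) is therefore expected, none beyond the scatter. Compound 4 is estimated at 58%, in the range 40% to 75%.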

Compound 4, a percentage reported as inhibition, at one concentration (the size of the read-out at that concentration, not a potency): 99.6%
Compound 4: the middle estimate sits 41.6 percentage points below what was measured, outside the stated range (above it).
By their numbers in this assay, from the lowest: compounds 3 and 2 (each within the scatter of the next); then compound 1; then compound 4.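

In this assay, methoxy in place of hydrogen on the aromatic carbon para to an amino group gives a number 39.1 percentage points higher from compound 2 to compound 4 (beyond the scatter), so with the trifluoromethyl amidine in place, this position is far from indifferent to substitution. The earlier compounds shown here held no matched pair for this change, and so could not show this. No measurement here accounts for the size of the step. As far as these compounds go, whether a hydroxy or an ethoxy at this position would move the number the same way remains open, as does whether a methoxy would do so alongside the chloro of compound 1.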